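The compounds below may be only part of what the source reports. "The series", "measured", "known", "first", "only" and "open" are said of these compounds alone.

Measured compounds:
compound 1, `Cc1c(OCCCCOc2ccccc2C(=O)O)ccc(C(=O)CC(C)C)c1O`, 92.4%
compound 2, `Cc1c(OCCCCOc2ccccc2C(=O)O)ccc(C(=O)CC2CCCC2)c1O`, 98.8%
compound 3, `Cc1c(OCCCCOc2ccccc2C(=O)O)ccc(C(=O)CC(C)C)c1C`, 76.2%

In an assay on HEK293 cells for positive allosteric modulation of metabotropic glutamate receptor 2 (Rattus norvegicus), read by thallium flux, with a stated time of 2.5 min (on this read-out lower numbers stand for smaller maximal responses and higher numbers for larger maximal responses), compound 1 gives 92.4%, the second highest of the three numbers. The nearest is compound 2 with 98.8%; that step, a number 6.4 percentage points higher from compound 1 to compound 2 (within the scatter), stays within the scatter. The furthest is compound 3 with 76.2%; that step, a number 16.2 percentage points lower from compound 1 to compound 3 (beyond the scatter), is a modest change beyond the scatter.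

Compound 4, `Cc1cc(C(=O)O)ccc1OCCCCOc1ccc(C(=O)CC(C)C)c(O)c1C`, differs from compound 1 in one place: 4-carboxy-2-methylphenyl in place of 2-carboxyphenyl on an oxygen on a saturated carbon. Neither measured step bears on this change. The step from compound 1 to compound 2 alters the group bound to the carbonyl carbon, and the step from compound 1 to compound 3 alters a group on the shared core; both leave the 2-carboxyphenyl untouched. Among the compounds with values here, no measured compound varies that end of the molecule, so the direction of the step in this assay for compound 4 is unknown. With all three measured values high, compound 4 is expected to give 85%, a step of a number 7.4 percentage points lower from compound 1 to compound 4 (within the scatter), with a range from 60% to 100% reflecting the lack of direct precedent.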

Compound 4, largest response reached (reported as percent of maximum), in percent of the reference or control that the assay uses: 83.9%
Beside the measured number, compound 4's estimate is 1.1 percentage points above it; the measured number falls inside the stated range.
By their numbers in this assay, from the lowest: compounds 3, 4, 1 and 2 (each within the scatter of the next, the first and the last beyond it).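

In this assay the change to 4-carboxy-2-methylphenyl in place of 2-carboxyphenyl gives a number 8.5 percentage points lower from compound 1 to compound 4 (within the scatter). This shows what compound 2 and compound 3, which both keep the 2-carboxyphenyl, could not: this end of the molecule can be altered without a step beyond the scatter. The change moves the carboxy group on the ring and adds a methyl in a single step, so a response within the scatter of compound 1 does not require the 2-carboxyphenyl itself. No measurement given here explains this tolerance.

The compounds shown do not separate the moved carboxy group from the added methyl, as each appears only in this one combination. They also leave open whether a tetrazole or a primary amide could stand in place of the carboxy group on this ring.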